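The source may report more compounds than this note shows. Statements on the series, on what has been measured and on what is new or still open speak of the compounds shown alone.

Compound 1, `O=C1C=C(NCc2ccccc2)C(=O)c2c1nc1n2[C@H]2OC[C@@H](O)[C@H]2OC1`, was tested in a functional assay on MCF7 cells (Homo sapiens) for inhibition, read by sulforhodamine B assay; on this read-out lower numbers stand for stronger inhibition and higher numbers for weaker inhibition. In this assay compound 1 gives > 8000 nM, which is a limit of the assay rather than a number. A second compound, compound 2, `O=C1C(N2CCCCC2)=CC(=O)c2c1nc1n2[C@H]2OC[C@@H](O)[C@H]2OC1`, stands beside it. In this assay compound 2 gives > 8000 nM, again a limit and not a number. Among the measured compounds shown here, compound 1 therefore stands only as a limit, and the one further value shown is a limit as well; this is summed up by the limit of > 8000 nM in this assay, at which 2 of the 2 values shown sit. For the measured compounds named here, no step between two measured compounds exists here, since neither value is a number. The next compound, compound 3, `Cc1ccc(NC2=CC(=O)c3nc4n(c3C2=O)[C@H]2OC[C@@H](O)[C@H]2OC4)cc1C`, has not yet been measured. It differs from compound 1 in a single place: 3,4-dimethylphenyl in place of benzyl on an amine nitrogen. With only limits on either side, the data give no direction for this change. The expected step is a step that the limit leaves unreadable from compound 1 to compound 3, which is taken to be none beyond the scatter. For compound 3 the estimate in this assay is 10000 nM, with a range from 3000 nM to 30000 nM, and it is expected that the assay again reports only a limit.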

Compound 3, half-maximal inhibitory concentration: 2080 nM
Compound 3: the middle estimate sits 4.8-fold (0.68 log units) above what was measured; the measured number lies below the stated range.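

In this assay, among the compounds shown here, 3,4-dimethylphenyl in place of benzyl on an amine nitrogen gives an at least 3.8-fold lower number from compound 1 to compound 3 (0.58 log units; beyond the scatter), so the group on this nitrogen does bear on the read-out, and the change now has a direction that the earlier compounds could not give. Compound 3 is the only compound shown with a number rather than a limit: the limit of > 8000 nM in this assay, at which 2 of the 3 values shown sit. The change is also a double one, as the ring now sits directly on the nitrogen without the carbon link of benzyl and carries two methyl groups, so the step cannot be credited to either part alone.

Plain phenyl and 3,4-dimethylbenzyl on the same nitrogen would separate those two parts, and the compounds shown do not say which part carries the step. From the compounds shown here alone, it also remains open whether chloro or methoxy in place of the methyl groups, or a cyclohexyl group on this nitrogen, would keep a measurable number in this assay.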